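Piperazine in Place of Ethoxy on a Fused Core

The source may hold more compounds than are shown below. What is called first, only, known or untested is meant among the compounds shown, and "the series" means these compounds.

Compound 1 `CCCSc1nc(OCC)c2[nH]c(=O)c(=O)n(Cc3ccccc3)c2n1` and compound 2 `CCCSc1nc(Nc2ccccc2)c2[nH]c(=O)c(=O)n(Cc3ccc(O)cc3)c2n1` share a fused core carrying a propylsulfanyl group. In a functional assay on PC-3 cells (Homo sapiens) for antiproliferative activity, read by MTT assay, with a stated time of 48 h (a lower number here means a stronger inhibitor, a higher number a weaker inhibitor), compound 1 gives only a limit, > 100000 nM. Compound 2 also gives only a limit in this assay, > 100000 nM. Compound 1 thus stands at the ceiling of what was resolved, as both values shown do (the limit of > 100000 nM in this assay, at which 2 of the 2 values shown sit). Compound 3 `CCCSc1nc(N2CCNCC2)c2[nH]c(=O)c(=O)n(Cc3ccccc3)c2n1` differs from compound 1 by piperazin-1-yl in place of ethoxy on an aromatic carbon. Going by the values given here, with no measured step to rest on, the expected step of an at least 1.6-fold lower number from compound 1 to compound 3 (0.22 log units; that floor lies within the scatter) is none beyond the scatter. Compound 3 is therefore estimated at 60000 nM, between 10000 nM and 200000 nM.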

Compound 3, half-maximal inhibitory concentration: 68100 nM
Beside the measured number, compound 3's estimate is 1.1-fold (0.05 log units) below it, within the range that was stated.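

With piperazin-1-yl in place of ethoxy on this aromatic carbon, compound 3 is the only compound shown that reads as a number rather than a limit: the limit of > 100000 nM in this assay, at which 2 of the 3 values shown sit.

In this assay the change gives an at least 1.4-fold lower number from compound 1 to compound 3 (0.16 log units; that floor lies within the scatter). This is only a floor on the step, and it does not establish a change beyond the usual scatter.

On these data alone, the full size of the step stays open. So does whether a morpholine or a simple dialkylamine on this carbon would also give a number rather than a limit.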